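The source may hold more compounds than are shown below. What is called first, only, known or untested is meant among the compounds shown, and "the series" means these compounds.

Within the data shown here, compound 1 (`CN(C)C(=O)c1cc2cnc(Nc3ccc(NC(=O)C4(C(=O)Nc5ccccc5F)CC4)cc3)nc2n1C1CCCC1`) gives 88.6% in a functional assay on A549 cells (Homo sapiens) for inhibition, read by CCK-8 assay, with a stated time of 72 h, tested at 10 uM (a lower number here means less inhibition of growth, a higher number more inhibition of growth at the concentration tested), and holds the higher of the two numbers known so far. Compound 2 (`Nc1ccc(NC(=O)C2(C(=O)Nc3ccc(F)cc3)CC2)cc1F`) gives 14.6% in this assay and so sits far lower, by a gap beyond the usual scatter. These two compounds differ in more than one place, so their gap cannot be pinned on any single group.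

Compound 3 (`CN(C)C(=O)c1cc2cnc(Nc3ccc(NC(=O)C4(C(=O)Nc5cccc(C(F)(F)F)c5)CC4)cc3)nc2n1C1CCCC1`) keeps the core of compound 1 and alters one group, with 3-(trifluoromethyl)phenyl in place of 2-fluorophenyl on an amide-type nitrogen. Among the measured compounds shown here, no measured pair shows what this swap does, so the expectation is only a cautious one. With compound 1 at 88.6% there is little room left for a rise, and a change in one group could lower the number. The expected step of a number 8.6 percentage points lower from compound 1 to compound 3 (within the scatter) is therefore a small fall that may stay within the scatter. For compound 3 the estimated growth inhibition is 80% with an expected range from 58% to 95% in this reading.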

Compound 3, percent growth inhibition at one concentration: 89.2%
The estimate for compound 3 lay 9.2 percentage points below the measured number; measured number inside the range.
By their numbers in this assay, from the lowest: compound 2; then compounds 1 and 3 (each within the scatter of the next).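

In this assay, putting 3-(trifluoromethyl)phenyl in place of 2-fluorophenyl on the amide-type nitrogen gives a number 0.6 percentage points higher from compound 1 to compound 3 (within the scatter), and this is the first pair shown that differs in one place only. It shows that, with the core of compound 1 kept, this position can take a group of 10 heavy atoms instead of 7, with a different fluorine substituent, and the growth inhibition stays within the scatter at the single concentration tested. Nothing given here offers an explanation for this result.

Both compounds sit high on the percent scale, so this one reading cannot tell whether they would still match at lower concentrations, where a difference might appear that is hidden here. Going by these compounds, it also remains open whether the position accepts other kinds of group on the same nitrogen, such as an unsubstituted phenyl, a cyclohexyl ring or a short alkyl chain, or whether an aromatic ring carrying fluorine is needed to keep growth inhibition at this level.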